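The source may hold more compounds than are shown below. What is called first, only, known or untested is meant among the compounds shown, and "the series" means these compounds.

Compounds measured in a functional assay on CHO cells with sphingosine 1-phosphate receptor 2 (Homo sapiens) as the target, read by GTPgammaS binding; on this read-out higher numbers stand for an effect only at larger amounts of compound and lower numbers for an effect already at smaller amounts:
Compound 1, `Cc1ccccc1-c1noc(-c2ccc(C3CCCCC3)cc2)n1`, gives > 10000 nM, which is a limit of the assay.
Compound 2, `CCCCc1ccc(-c2nc(-c3ccc(CCC(=O)O)cc3C)no2)nc1`, gives > 10000 nM, which is a limit of the assay.
Compound 3, `Cc1cc(CCC(=O)O)ccc1-c1noc(-c2ccc(CC(C)C)cn2)n1`, gives > 10000 nM, which is a limit of the assay.

Compound 3 therefore stands where the whole set stands, at the limit of > 10000 nM in this assay, at which 3 of the 3 values shown sit. Going by the values given here, no compound here yields a number. Among the compounds with values here, the one pairwise step among the measured compounds, a step that the two limits leave unreadable from compound 2 to compound 3, has limits at both ends and its size cannot be read.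

Compound 4, `Cc1cc(CCC(=O)O)ccc1-c1noc(-c2ccc(C(F)(F)C(C)C)cn2)n1`, has not yet been measured in this assay. It differs from compound 3 by 1,1-difluoro-2-methylpropyl in place of isobutyl on an aromatic carbon. Within the data shown here, the only measured step touches the same chain on the same ring, but it gives no size, and no measured pair involves fluorine at all. The data thus offer no readable step that bears on this change, in either direction.

With every measured value sitting at the limit, compound 4 is expected to stay there as well. The step that this expectation implies, a step that the limit leaves unreadable from compound 3 to compound 4, is estimated as none beyond the scatter. For compound 4 in this assay the estimate is 15000 nM, with a range from 4000 nM to 60000 nM, and the assay is expected most likely to report a limit again rather than a number.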

Compound 4, half-maximal effective concentration: > 10000 nM
Compound 4 was reported as a limit (the forecaster's own chance of this, stated with the estimate: 75%); the middle value is on the limit's open side.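

In this assay compound 4 gives > 10000 nM, which is a limit of the assay. No step can be read from compound 3 or compound 2 to compound 4, as each pair has limits at both ends. The compounds shown leave open how large an effect, if any, 1,1-difluoro-2-methylpropyl in place of isobutyl has, and what amount of any of these compounds would give a numerical value: the limit of > 10000 nM in this assay, at which 4 of the 4 values shown sit.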